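The compounds below may be only part of what the source reports. "The series", "measured", "known", "first", "only" and "open" are said of these compounds alone.

Measured compounds in the series:
compound 1, `COc1ccc(CNC(=O)CN2C(=O)/C(=C/c3ccc(-c4ccc(Cl)cc4)o3)SC2=S)cc1`, 40000 nM
compound 2, `Cc1ccc(CNC(=O)CN2C(=O)/C(=C/c3ccc(-c4ccc(Cl)cc4)o3)SC2=S)cc1`, 45000 nM
compound 3, `O=C(CN1C(=O)/C(=C/c2ccc(-c3ccc(Cl)cc3)o2)SC1=S)NCc1ccc(Br)cc1`, 68000 nM

All three share one core and differ only in the substituent on the benzyl ring. In a functional assay on K562 cells (Homo sapiens) for cytotoxicity, read by MTT assay, with a stated time of 72 h (on this read-out higher numbers stand for weaker inhibition and lower numbers for stronger inhibition), compound 3 gives the highest of the three numbers, but its steps to the others are both within the scatter: a 1.7-fold higher number from compound 1 to compound 3 (0.23 log units; within the scatter) and a 1.5-fold higher number from compound 2 to compound 3 (0.18 log units; within the scatter). The remaining step, a 1.1-fold higher number from compound 1 to compound 2 (0.05 log units; within the scatter), is likewise within the scatter. On the numbers shown, then, no compound can be called weaker or stronger than another.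

Compound 4, `Cc1cccc(CNC(=O)CN2C(=O)/C(=C/c3ccc(-c4ccc(Cl)cc4)o3)SC2=S)c1`, is not yet measured. Compared with compound 3 the change is 3-methylphenyl in place of 4-bromophenyl on a saturated chain carbon bound to an amide-type nitrogen. Among the compounds with values here, no measured pair covers this exact change; the closest comparison is the step between compound 2 and compound 3, where bromo replaced methyl on an aromatic carbon and the number moved only within the scatter. With that step and the two others all within the scatter, a step no larger than the scatter is expected from compound 3 to compound 4, a 1.4-fold lower number from compound 3 to compound 4 (0.13 log units; within the scatter), direction undetermined. Compound 4 is therefore estimated at 50000 nM in this assay, with a range of 25000 nM to 100000 nM.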

Compound 4, half-maximal inhibitory concentration: 48000 nM
Beside the measured number, compound 4's estimate is 1.0-fold (0.02 log units) above it, and the stated range covers the measured number.
By their numbers in this assay, from the lowest: compounds 1, 2, 4 and 3 (each within the scatter of the next).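

Compound 4 brings the first 3-substituted ring into the series, at the same place on a saturated chain carbon bound to an amide-type nitrogen, and in this assay the exchange of 4-methylphenyl for 3-methylphenyl stays within the scatter (a 1.1-fold higher number from compound 2 to compound 4 (0.03 log units; within the scatter)). The exchanges of the other two groups for 3-methylphenyl also stay within the scatter (a 1.4-fold lower number from compound 3 to compound 4 (0.15 log units; within the scatter); a 1.2-fold higher number from compound 1 to compound 4 (0.08 log units; within the scatter)), so this read-out separates neither the substituent type nor its ring position among these four compounds, although each comparison with compound 1 or compound 3 changes both the substituent and its ring position. No measurement at hand speaks to why the numbers at this place stay so close.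

Going by these compounds, all four compounds carry a substituted phenyl at this place and leave the rest of the shared core unchanged, so it remains open whether any change here can move the number beyond the scatter. A basic amine such as dimethylaminomethyl, a carboxylic acid on the ring, or a longer chain between the amide nitrogen and the ring would test this, as would 3-bromophenyl and 3-methoxyphenyl for the ring position alone.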